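A chloro step on compound 1

The source may report more compounds than this note shows. Statements on the series, on what has been measured and on what is new or still open speak of the compounds shown alone.

In a functional assay on HeLa cells (Homo sapiens) for antiproliferative activity, read by MTT assay, with a stated time of 48 h (a lower number here means a stronger inhibitor, a higher number a weaker inhibitor), compound 1 `CN(C)CCn1c(N)c(-c2nc3ccccc3[nH]2)c2nc(C#N)c(C#N)nc21` gives 8880 nM, the higher of the two exact numbers in this small set. Compound 2 `CCN(CC)CCCn1c(N)c(-c2nc3ccccc3[nH]2)c2nc(C#N)c(C#N)nc21`, with (diethylamino)methyl in place of dimethylamino on a saturated chain carbon, gives 3150 nM. Compound 3 `CN(C)CCn1c(N)c(-c2nc3ccccc3n2C)c2nc(C#N)c(C#N)nc21`, with methyl in place of hydrogen on an aromatic nitrogen, is reported only as a limit, > 50000 nM.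

Compound 4 `CN(C)CCn1c(N)c(-c2nc3cc(Cl)ccc3[nH]2)c2nc(C#N)c(C#N)nc21` has chloro in place of hydrogen on an aromatic carbon, (chloro in place of hydrogen on an aromatic carbon). Neither measured step touches that carbon, so both offer only a rough scale for the change. The chain change gives a 2.8-fold lower number from compound 1 to compound 2 (0.45 log units; beyond the scatter). The methyl on the aromatic nitrogen gives an at least 5.6-fold higher number from compound 1 to compound 3 (0.75 log units; beyond the scatter), but that step lies at a nitrogen and ends in a limit, so it carries less weight here. A modest step toward a lower number in this assay is therefore expected, similar in size to the step to compound 2, although the direction remains uncertain. The estimate is a 2.2-fold lower number from compound 1 to compound 4 (0.35 log units; beyond the scatter). For compound 4 the expected value is 4000 nM, with an estimated range from 1500 nM to 15000 nM.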

Compound 4, half-maximal inhibitory concentration: > 50000 nM
Compound 4 ended at the assay's limit (the forecaster's own chance of this, stated with the estimate: 5%); at least 12-fold (1.09 log units) between middle value and limit.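

Chloro in place of hydrogen on this aromatic carbon gives an at least 5.6-fold higher number from compound 1 to compound 4 (0.75 log units; beyond the scatter) in this assay. The value of compound 4, > 50000 nM, is a limit and not a number, so this step gives only a lower bound on the size of the change. Among the earlier compounds, only the methyl on the aromatic nitrogen had produced a step ending at a limit, so this aromatic carbon of the six-membered ring of carbon only is a second place in the shared core where one small change has that outcome: the limit of > 50000 nM in this assay, at which 2 of the 4 values shown sit.

With chloro as the only group shown at this carbon, it remains open whether fluoro, methyl or methoxy there would also end at the limit, or would keep a measurable number in this assay. On these data alone, it is also open whether chloro on the other aromatic carbons of that ring would behave in the same way, and whether the (diethylamino)methyl chain end of compound 2 would change the outcome with chloro in place.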